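Amine substituent changes on the shared core: notes toward compound 4

A few compounds are considered here, and "the series" means these few. Any claim that something is new, unique, unknown or untested is made for them only; others in the source may bear on it.

Measured so far in a functional assay on KB cells (Homo sapiens) for cytotoxicity, read by MTT assay, with a stated time of 72 h; a higher number here means a weaker inhibitor, a lower number a stronger inhibitor:
compound 1 `CCCCN(CCCC)c1nc2c(ncn2-c2ccccc2)c(=O)n1-c1ccccc1` gives 9500 nM
compound 2 `CC(C)N(c1nc2c(ncn2-c2ccccc2)c(=O)n1-c1ccccc1)C(C)C` gives 53500 nM
compound 3 `O=c1c2ncn(-c3ccccc3)c2nc(N2CCCCC2)n1-c1ccc(Cl)cc1` gives 72800 nM

Compound 3 stands at the highest number of the three; compound 2 lies within the scatter of it, while compound 1 lies below it beyond the scatter. Compound 4 `CNc1nc2c(ncn2-c2ccccc2)c(=O)n1-c1ccc(Cl)cc1` differs from compound 3 by methylamino in place of piperidin-1-yl on an aromatic carbon. Going by the values given here, the only measured step at this position is a 5.6-fold higher number from compound 1 to compound 2 (0.75 log units; beyond the scatter), a swap between two dialkylamino groups, which shows that the amine substituent can move this assay beyond the scatter. Among the compounds with values here, no measured pair covers a methylamino group, so the direction cannot be read from compound 1 and compound 2. Compound 4 is therefore expected close to compound 3, with an estimated step of a 1.2-fold lower number from compound 3 to compound 4 (0.08 log units; within the scatter). The estimate for compound 4 is 60000 nM, expected within 15000 nM to 200000 nM.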

Compound 4, half-maximal inhibitory concentration: > 100000 nM
Compound 4: no number, only a limit; the forecaster's own chance of this, stated with the estimate: 30%; at least 1.6-fold (0.22 log units) between middle value and limit.
By their numbers in this assay, from the lowest: compound 1; then compounds 2 and 3 (each within the scatter of the next). At a limit, above all of these: compound 4.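

In this assay methylamino in place of piperidin-1-yl on this aromatic carbon gives an at least 1.3-fold higher number from compound 3 to compound 4 (0.13 log units; that floor lies within the scatter) and brings no lower number in this pair. Compound 4 is the only compound shown that ends at a limit and not at a number: the limit of > 100000 nM in this assay, at which 1 of the 4 values shown sits. The swap removes the ring and adds a hydrogen-bond donor, yet the limit leaves the true size of the step unread.

Open, from the compounds shown here alone, is how an unsubstituted amino group, an ethylamino chain or a morpholin-4-yl ring would read at this position on the core of compound 3.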